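Aryl ester back in place of sulfonamide on the cyclohexane

The compounds below may be only part of what the source reports. "The series", "measured", "known", "first", "only" and "open" are said of these compounds alone.

Of the compounds shown here, three have numbers so far. In an ADME assay on cells (Hepatocyte, Homo sapiens) for metabolic stability, with a stated time of 30 min (a lower number here means that less of the compound is left, a higher number that more of the compound is left), compound 1 `Nc1cc(C(F)(F)F)cc2c(=O)cc(N3CCN(CC4CCC(O)CC4)CC3)sc12` gives 72.9%, compound 2 `O=C(OC1CCC(CN2CCN(c3cc(=O)c4cc(C(F)(F)F)cc([N+](=O)[O-])c4s3)CC2)CC1)c1ccco1` gives 1% and compound 3 `CS(=O)(=O)NC1CCC(CN2CCN(c3cc(=O)c4cc(C(F)(F)F)cc([N+](=O)[O-])c4s3)CC2)CC1` gives 105%. Compound 3 stands highest of the three; compound 1 is nearest, compound 2 furthest. Within the data shown here, the one single-point step measured so far is a number 104 percentage points higher from compound 2 to compound 3 (beyond the scatter), in which the methanesulfonamido took the place of the ((furan-2-yl)carbonyl)oxy on the saturated ring carbon.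

Compound 4 `O=C(OC1CCC(CN2CCN(c3cc(=O)c4cc(C(F)(F)F)cc([N+](=O)[O-])c4s3)CC2)CC1)c1ccc(F)cc1` reverses that kind of change: ((4-fluorophenyl)carbonyl)oxy in place of methanesulfonamido on a saturated ring carbon. An ester of an aromatic acid thus returns to the same saturated ring carbon, as in compound 2, which had the lowest number of the set. The step from compound 2 to compound 3 is the one that bears directly here, and it was large; the step from compound 3 to compound 4 is therefore expected to be large as well, downward, bringing compound 4 close to the level of compound 2. For compound 4 the estimate in this assay is 5%, within 1% to 25%, an expected step of a number 100 percentage points lower from compound 3 to compound 4 (beyond the scatter).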

Compound 4, percent of the compound remaining: 3%
Beside the measured number, compound 4's estimate is 2 percentage points above it, within the range that was stated.
By their numbers in this assay, from the lowest: compounds 2 and 4 (each within the scatter of the next); then compound 1; then compound 3.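

In this assay the step of a number 102 percentage points lower from compound 3 to compound 4 (beyond the scatter) shows that the low number on this saturated ring carbon does not belong to the furan-2-yl ester alone: a second aromatic ester, ((4-fluorophenyl)carbonyl)oxy, also stands far from the methanesulfonamido. The step of a number 2 percentage points higher from compound 2 to compound 4 (within the scatter) shows that 4-fluorophenyl in place of furan-2-yl on a carbonyl carbon does not separate the two esters, so this exchange of the aromatic ring gives no readable change here. Nothing at hand gives a reason for the numbers of either ester.

From the compounds shown here alone, it remains open whether the low numbers go with the ester link or with the aromatic acid part. An acetate ester or a benzamide on the same saturated ring carbon would bear on that question.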